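This account rests on a few compounds, and the source may have more. Where it says the series, first, only, none or still open, it means among the compounds named here.

Working notes on the series. For the measured compounds named here, compound 3 `Cc1cc(C)cc(CNc2cncc(-c3cc(C)cc(C)c3)c2N2CCC(N)CC2)c1` gives in a functional assay on CHO-K1 cells for agonist activity at somatostatin receptor type 2 (Homo sapiens), read by cAMP accumulation, with a stated time of 30 min (on this read-out higher numbers stand for an effect only at larger amounts of compound and lower numbers for an effect already at smaller amounts), a value of 0.8 nM, the highest of the three numbers measured so far. Compound 1 `Cc1nn(C)cc1C(=O)Nc1cncc(-c2cc(Cl)cc(Cl)c2)c1N1CCC(N)CC1` gives 0.12 nM and compound 2 `Cc1cc(C)cc(-c2cncc(-c3nc4cc(C)cc(C)c4[nH]3)c2N2CCC(N)CC2)c1` gives 0.013 nM; both gaps to compound 3 lie beyond the scatter, so compound 3 stands as the weakest of the three measured. No pair among these three differs in a single place, so any comparison between them mixes several changes at once.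

Compound 4 `Cc1cc(C)cc(C(=O)Nc2cncc(-c3cc(C)cc(C)c3)c2N2CCC(N)CC2)c1` is not yet measured. It differs from compound 3 in one place: (3,5-dimethylphenyl)carbonyl in place of 3,5-dimethylbenzyl on a nitrogen on an aromatic ring. Compound 1 also holds a carbonyl in this part of the molecule and gives 0.12 nM, a lower number than compound 3, but compound 1 differs from compound 3 elsewhere as well, so this is only a hint. The change is expected to lower the number for compound 4, with a step of a 5.3-fold lower number from compound 3 to compound 4 (0.73 log units; beyond the scatter) reaching beyond the scatter. Compound 4 is estimated at 0.15 nM, with a range from 0.03 nM to 0.8 nM.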

Compound 4, half-maximal effective concentration: 0.04 nM
The estimate for compound 4 lay 3.8-fold (0.57 log units) above the measured number, within the range that was stated.
By their numbers in this assay, from the lowest: compound 2; then compound 4; then compound 1; then compound 3.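

For the compounds shown here, at the nitrogen on the aromatic ring, (3,5-dimethylphenyl)carbonyl in place of 3,5-dimethylbenzyl gives a 20-fold lower number from compound 3 to compound 4 (1.30 log units; beyond the scatter) in this assay and is the first change that can be read at a single place. The hint from compound 1 thus gains direct support from a matched pair, and the read-out proves sensitive to this one change in the group on that nitrogen. Nothing measured here bears on why the number falls.

The compounds shown leave open whether the carbonyl itself is what matters, since a sulfonyl group or a longer chain in its place would separate it from the other features of the group. On these data alone, it also remains open whether the same step would appear with the other groups on the core of compound 1.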